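A few compounds are considered here, and "the series" means these few. Any claim that something is new, unique, unknown or untested is made for them only; others in the source may bear on it.

Compound 1 `COc1c(/C=C2/C(=O)Nc3ccccc32)c2ccccc2n1-c1ccccc1` and compound 3 `COc1c(/C=C2/C(=O)Nc3ccc(Cl)cc32)c2ccccc2n1-c1ccccc1` share one core and differ by a single change, (chloro in place of hydrogen on an aromatic carbon). In a functional assay on NSCLC cells (Homo sapiens) for cytotoxicity, with a stated time of 48 h (on this read-out higher numbers stand for weaker inhibition of growth and lower numbers for stronger inhibition of growth), compound 1 gives 2140 nM, while compound 3 gives 9550 nM, a step of a 4.5-fold higher number from compound 1 to compound 3 (0.65 log units; beyond the scatter). Compound 2 `O=C1Nc2ccccc2/C1=C\c1c(Cl)n(CCCc2ccccc2)c2ccccc12` carries a different core; the difference between the two cores is not broken down here. In this assay compound 2 gives 14100 nM, which sits within the scatter of compound 3 and beyond it relative to compound 1.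

Compound 4 `O=C1Nc2ccc(Cl)cc2/C1=C\c1c(Cl)n(CCCc2ccccc2)c2ccccc12` is the counterpart of compound 2 still to be measured in this assay, and it differs from compound 2 by chloro in place of hydrogen on an aromatic carbon. The place of this change is described in the same words as for the pair of compound 1 and compound 3, so it is the same change made on the second core, occurring twice in all among the compounds shown.

With only one measured case of this change, on a different core, the expected step in this assay is a 2.8-fold higher number from compound 2 to compound 4 (0.45 log units; beyond the scatter), set beside the measured 4.5-fold higher number from compound 1 to compound 3 (0.65 log units; beyond the scatter) and resting on that single precedent with wide uncertainty. Compound 4 is accordingly estimated at 40000 nM, with a range from 14000 nM to 120000 nM.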

Compound 4, concentration for 50% growth inhibition: 2240 nM
Beside the measured number, compound 4's estimate is 18-fold (1.25 log units) above it; measured number below the stated range.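

In this assay, chloro in place of hydrogen on an aromatic carbon gives a 6.3-fold lower number from compound 2 to compound 4 (0.80 log units; beyond the scatter), so on the core of compound 2 the change goes with stronger inhibition of growth. On the core of compound 1 the same change runs the opposite way, and the step does not carry over from one core to the other: the same change on two cores in this assay, a 4.5-fold higher number (0.65 log units; beyond the scatter) from compound 1 to compound 3 and a 6.3-fold lower number (0.80 log units; beyond the scatter) from compound 2 to compound 4, 28-fold (1.45 log units) apart, beyond the scatter of two such steps. This shows that, across these two pairs, both the size and the direction of the step depend on the core, but it does not show which difference between the cores decides the direction, and two pairs give no rule for any further core.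

Still open, as far as these compounds go, is whether a fluoro or bromo group, or an amine, in the place of this chloro would follow the same split between the two cores. Also open, from the compounds shown here alone, is whether the direction of the step follows the methoxy and phenyl groups of compound 1 or the chloro and longer chain of compound 2.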